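Benzylselanyl for methylsulfanyl on two quinoline amide cores

The source may hold more compounds than are shown below. What is called first, only, known or untested is meant among the compounds shown, and "the series" means these compounds.

Compound 2 `CS/C(=N\C(=O)c1cc(-c2ccccc2)nc2ccccc12)NC(=O)c1cc(-c2ccccc2)nc2ccccc12` gives 40 nM in an ADME assay on MCF-10A cells (Homo sapiens) for cytotoxicity, read by MTT assay, with a stated time of 72 h; on this read-out lower numbers stand for stronger inhibition of growth and higher numbers for weaker inhibition of growth. Compound 1 `O=C(/N=C(/NC(=O)c1cc(-c2ccccc2)nc2ccccc12)[Se]Cc1ccccc1)c1cc(-c2ccccc2)nc2ccccc12` carries a group of 8 heavy atoms (7 carbon, 1 selenium; one six-membered aromatic ring of carbon only) in place of a group of 2 heavy atoms (1 carbon, 1 sulfur; no ring), on a carbon with a double bond to nitrogen; in this assay compound 1 gives 8460 nM, a step of a 210-fold higher number from compound 2 to compound 1 (2.33 log units; beyond the scatter). Compound 3 `CS/C(=N\C(=O)c1cnc2ccccc2c1)NC(=O)c1cnc2ccccc2c1` is the methylsulfanyl member on a second core; the difference between the two cores is not broken down here. In this assay compound 3 gives 500 nM, standing between compound 2 and compound 1. Compound 4 `O=C(/N=C(/NC(=O)c1cnc2ccccc2c1)[Se]Cc1ccccc1)c1cnc2ccccc2c1` is not yet measured and carries a group of 8 heavy atoms (7 carbon, 1 selenium; one six-membered aromatic ring of carbon only) in place of a group of 2 heavy atoms (1 carbon, 1 sulfur; no ring), on a carbon with a double bond to nitrogen, the same change at the same place as from compound 2 to compound 1. The change occurs only twice among the compounds shown, so the expectation rests solely on the step of a 210-fold higher number from compound 2 to compound 1 (2.33 log units; beyond the scatter). The step from compound 3 to compound 4 is expected to be an 80-fold higher number from compound 3 to compound 4 (1.90 log units; beyond the scatter), taken somewhat smaller than that single precedent. Compound 4 is therefore estimated at 40000 nM in this assay, with a range from 10000 nM to 150000 nM.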

Compound 4, concentration for 50% growth inhibition: 23600 nM
Compound 4: the middle estimate sits 1.7-fold (0.23 log units) above what was measured, within the range that was stated.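

In this assay, benzylselanyl in place of methylsulfanyl again gives a large move towards weaker inhibition of growth on the second core (a 47-fold higher number from compound 3 to compound 4 (1.67 log units; beyond the scatter)). The direction of the change carries from one core to the other, but its size does not: the same change on two cores in this assay, a 210-fold higher number (2.33 log units; beyond the scatter) from compound 2 to compound 1 and a 47-fold higher number (1.67 log units; beyond the scatter) from compound 3 to compound 4, 4.5-fold (0.65 log units) apart, beyond the scatter of two such steps.
For the compounds shown here, with only two cores, these steps do not give the size of the change on any further core of the series.

The compounds shown leave open whether the step follows the selenium or the aromatic ring, since the two enter together. Methylselanyl and benzylsulfanyl on the carbon with a double bond to nitrogen would separate them, and an amine at that place remains open too.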